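The source may report more compounds than this note shows. Statements on the series, on what has been measured and on what is new or still open speak of the compounds shown alone.

Measured so far:
compound 1, `Cc1cc(S(N)(=O)=O)ccc1NC(=O)COc1ccc(Cl)cc1NC(=O)c1cccc(Cl)c1` — 59700 nM
compound 2, `Cc1cc(S(N)(=O)=O)ccc1NC(=O)COc1ccc(Cl)cc1NC(=O)c1cccc([N+](=O)[O-])c1` — 58800 nM

Both compounds were tested in a functional assay on C8166 cells (Homo sapiens) for cytotoxicity, read by MTT assay; a lower number here means that less compound is tolerated, a higher number that more compound is tolerated. Among these two numbers compound 2 has the lowest reading, with compound 1 as its nearest neighbour, and the gap between them is the single step of a 1.0-fold lower number from compound 1 to compound 2 (0.01 log units; within the scatter), which lies within the scatter, so the two readings cannot be told apart.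

Compound 3, `Cc1cc(S(N)(=O)=O)ccc1NC(=O)COc1ccc(Cl)cc1NC(=O)c1ccc(Cl)c(Cl)c1`, has not yet been tested. It differs from compound 2 in one place: 3,4-dichlorophenyl in place of 3-nitrophenyl on a carbonyl carbon. Within the data shown here, the only measured step that bears on this change is the one already seen, a 1.0-fold lower number from compound 1 to compound 2 (0.01 log units; within the scatter), in which an exchange of nitro and chloro on an aromatic carbon left the reading unchanged within the scatter. The new change returns to chlorine on the same aromatic ring, now as a 3,4-dichlorophenyl, and nothing measured suggests a move beyond the scatter in this assay in either direction.

Compound 3 is therefore expected to give about 60000 nM, with a range from 30000 nM to 120000 nM. The expected step is a 1.0-fold higher number from compound 2 to compound 3 (0.01 log units; within the scatter).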

Compound 3, half-maximal cytotoxic concentration: 158000 nM
The estimate for compound 3 lay 2.6-fold (0.42 log units) below the measured number; measured number outside the range, above it.
By their numbers in this assay, from the lowest: compounds 2 and 1 (each within the scatter of the next); then compound 3.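

In this assay the group on this carbonyl carbon can change the reading after all: the earlier exchange of nitro and chloro gave a 1.0-fold lower number from compound 1 to compound 2 (0.01 log units; within the scatter) and could not be told apart from no change, whereas 3,4-dichlorophenyl in place of 3-nitrophenyl gave a 2.7-fold higher number from compound 2 to compound 3 (0.43 log units; beyond the scatter) and so moved beyond the scatter. A single added atom is enough for a similar move, since chloro in place of hydrogen on an aromatic carbon of this ring gave a 2.6-fold higher number from compound 1 to compound 3 (0.42 log units; beyond the scatter) and again meant that more compound was tolerated before the cells were harmed. No measurement among these compounds accounts for this rise.

On these data alone, what stays open is whether the rise belongs to chlorine itself or would also appear with another group at the same place on the ring, such as a methoxy group, an amine or a carboxylic acid. These three compounds also leave open whether adding further groups to this ring would keep raising the tolerated concentration or whether the effect would stop with this second chlorine.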